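The compounds below may be only part of what the source reports. "The series", "measured", "known", "first", "only" and "open" are said of these compounds alone.

Measured in an ADME assay on the whole organism (serum) with Homo sapiens as the target; a higher number here means that the compound lasts longer, a lower number that the compound disappears faster:
compound 1 `Cc1cn(C2CC(N=[N+]=[N-])C(COC(=O)NCCCC(=O)O)O2)c(=O)[nH]c1=O` — > 48 h (a limit of the assay)
compound 2 `Cc1cn(C2CC(N=[N+]=[N-])C(COC(=O)CCCN)O2)c(=O)[nH]c1=O` — 0.433 h
compound 3 `Cc1cn(C2CC(N=[N+]=[N-])C(COC(=O)OCCCCCCCCO)O2)c(=O)[nH]c1=O` — 0.0333 h

The value of compound 1 in this assay is a limit, not a number; it sits at the limit of > 48 h in this assay, at which 1 of the 3 values shown sits, so compound 1 stands at the top of the numbers shown and every step away from it is a lower bound. Compound 4 `Cc1cn(C2CC(N=[N+]=[N-])C(COC(=O)OCCCO)O2)c(=O)[nH]c1=O` differs from compound 1 in one place: 3-hydroxypropoxy in place of (3-carboxypropyl)amino on a carbonyl carbon. For the measured compounds named here, two measured steps bear on this: an at least 110-fold lower number from compound 1 to compound 2 (2.04 log units; beyond the scatter) and an at least 1400-fold lower number from compound 1 to compound 3 (3.15 log units; beyond the scatter). Compound 3 likewise carries an (8-hydroxyoctyl)oxy group on that carbonyl carbon, and a 13-fold lower number from compound 2 to compound 3 (1.11 log units; beyond the scatter). A large downward step is therefore expected for compound 4, an at least 480-fold lower number from compound 1 to compound 4 (2.68 log units; beyond the scatter), itself a lower bound. Compound 4 is estimated at 0.1 h, between 0.02 h and 0.5 h.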

Compound 4, half-life: 0.167 h
For compound 4 the middle estimate is 1.7-fold (0.22 log units) below the measured one; the measured number falls inside the stated range.
By their numbers in this assay, from the lowest: compound 3; then compound 4; then compound 2. At a limit, above all of these: compound 1.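

In this assay, 3-hydroxypropoxy in place of (8-hydroxyoctyl)oxy on this carbonyl carbon gives a 5.0-fold higher number from compound 3 to compound 4 (0.70 log units; beyond the scatter), so the length of the chain counts here, while 3-hydroxypropoxy in place of 3-aminopropyl gives a 2.6-fold lower number from compound 2 to compound 4 (0.41 log units; beyond the scatter). The step away from (3-carboxypropyl)amino remains large, with an at least 280-fold lower number from compound 1 to compound 4 (2.45 log units; beyond the scatter). Compound 1 is a limit of the assay, not a number: the limit of > 48 h in this assay, at which 1 of the 4 values shown sits.

Still open, going by these compounds, is which part of (3-carboxypropyl)amino goes with the long half-life, the carboxylic acid or the nitrogen link to the carbonyl. A carboxylic acid on an oxygen-linked chain and a nitrogen-linked chain ending in a hydroxy group would separate the two.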